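Swapping Acetyl for Methyl on a Ring Nitrogen

This account rests on a few compounds, and the source may have more. Where it says the series, first, only, none or still open, it means among the compounds named here.

Compound 1 `O=C(NCCCNc1nc(Nc2cccc(F)c2)ncc1Br)c1cccs1`: 9 nM
Compound 2 `CC(=O)N1CCC(C(=O)NCCCNc2nc(Nc3cccc(F)c3)ncc2Br)CC1`: 430 nM

Both compounds were tested in an assay on isolated protein for inhibition of serine/threonine-protein kinase TBK1 (Homo sapiens); a lower number here means a stronger inhibitor, a higher number a weaker inhibitor. In this assay compound 1 gives 9 nM, while compound 2 gives 430 nM. Among the compounds with values here, compound 2 therefore stands highest of the two numbers, its nearest neighbour being compound 1, and the single measured step, a 48-fold higher number from compound 1 to compound 2 (1.68 log units; beyond the scatter), is a large one that concerns the group on the carbonyl carbon.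

Compound 3 `CN1CCC(C(=O)NCCCNc2nc(Nc3cccc(F)c3)ncc2Br)CC1` is the next compound in line. It differs from compound 2 in one place: methyl in place of acetyl on an amine nitrogen in a ring. Within the data shown here, this change sits on the amine nitrogen in the ring, a position that no measured step touches; the step of a 48-fold higher number from compound 1 to compound 2 (1.68 log units; beyond the scatter) tells how much the carbonyl substituent matters but says nothing about what happens on that nitrogen. Among the measured compounds shown here, with no step bearing on it, the direction of the change cannot be read from the data, and the expectation stays close to compound 2 with wide uncertainty.

For compound 3 the expected value in this assay is 300 nM, with a range from 70 nM to 1500 nM. This amounts to an expected step of a 1.4-fold lower number from compound 2 to compound 3 (0.16 log units; within the scatter).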

Compound 3, half-maximal inhibitory concentration: 4300 nM
Estimate against measurement, compound 3: 14-fold (1.16 log units) below; the measured number lies above the stated range.
By their numbers in this assay, from the lowest: compound 1; then compound 2; then compound 3.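

The amine nitrogen in the ring turns out to matter: in this assay, methyl in place of acetyl at this position gives a 10-fold higher number from compound 2 to compound 3 (1.00 log units; beyond the scatter), so a change of only a few heavy atoms far from the core of the molecule still moves the number beyond the scatter. It also sharpens the picture on the carbonyl carbon, where 1-methylpiperidin-4-yl in place of thiophen-2-yl gives a 480-fold higher number from compound 1 to compound 3 (2.68 log units; beyond the scatter), a larger step than the one seen with 1-acetylpiperidin-4-yl, and thiophen-2-yl keeps the lowest number of the three groups. No measurement on hand explains why the acetyl compound has the lower number of the two piperidine compounds.

The compounds shown leave open whether the carbonyl of the acetyl is the part that counts, which a propanoyl, a methanesulfonyl or a plain hydrogen on the same nitrogen could help to settle. They also leave open whether a phenyl or a furan-2-yl on the carbonyl carbon would stay close to thiophen-2-yl or fall nearer the piperidine compounds.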